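The source may report more compounds than this note shows. Statements on the series, on what has been measured and on what is new or still open speak of the compounds shown alone.

Measured in a functional assay on A2780 cells (Homo sapiens) for cytotoxicity, read by MTT assay, with a stated time of 24 h; a lower number here means a stronger inhibitor, a higher number a weaker inhibitor:
compound 1, `CCCCC[C@@H](C[C@H](O)C[C@@H]1CC=CC(=O)O1)OC`, 35400 nM
compound 2, `CCCCC[C@H](C[C@@H](O)C[C@H]1CC=CC(=O)O1)OC`, 28900 nM
compound 3, `CCCCC[C@H](C[C@@H](O)C[C@@H]1CC=CC(=O)O1)OC`, 54500 nM

Compound 1 holds the second highest of the three numbers. Its nearest neighbour is reached by a 1.2-fold lower number from compound 1 to compound 2 (0.09 log units; within the scatter), its furthest by a 1.5-fold higher number from compound 1 to compound 3 (0.19 log units; within the scatter); the remaining step is a 1.9-fold higher number from compound 2 to compound 3 (0.28 log units; within the scatter). All three steps stay within the scatter, so the three stereoisomers cannot be placed in any order of potency on these numbers.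

Compound 4, `CCCCC[C@H](C[C@H](O)C[C@@H]1CC=CC(=O)O1)OC`, has not yet been measured in this assay. Relative to compound 1 the change is the two compounds have the same atoms and bonds and differ only in configuration as drawn: 1 of 3 stereo elements differ; a stereocentre at a saturated chain carbon is drawn S in compound 1 and R in compound 4.

The three measured steps are all of the same kind, because of the fact that compounds 1 and 2 differ only in the configuration as drawn, the fact that compounds 1 and 3 differ only in the configuration as drawn and the fact that compounds 2 and 3 differ only in the configuration as drawn show that every pair differs only in configuration, with one, two or all three stereocentres inverted, and none of these moves the number beyond the scatter. Going by the values given here, a single inversion at a chain carbon has no direct counterpart among them, but nothing suggests that configuration at any one centre matters in this assay. No step beyond the scatter is therefore expected for compound 4 in this assay, in either direction.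

Compound 4 is estimated at 38000 nM, within 19000 nM to 76000 nM. For compound 4 the expected step is a 1.1-fold higher number from compound 1 to compound 4 (0.03 log units; within the scatter).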

Compound 4, half-maximal inhibitory concentration: 22900 nM
Compound 4: the middle estimate sits 1.7-fold (0.22 log units) above what was measured, and the stated range covers the measured number.
By their numbers in this assay, from the lowest: compounds 4, 2, 1 and 3 (each within the scatter of the next, the first and the last beyond it).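

In this assay, going by these compounds alone, inverting a single stereocentre at a saturated chain carbon now gives the first step beyond the scatter, though only a modest one, with a 2.4-fold lower number from compound 3 to compound 4 (0.38 log units; beyond the scatter), and this pair differs in nothing else: the fact that compounds 3 and 4 differ only in the configuration as drawn. Inversion of one saturated chain carbon does not always have this outcome: a 1.5-fold lower number from compound 1 to compound 4 (0.19 log units; within the scatter) stays within the scatter, as does the double inversion in a 1.3-fold lower number from compound 2 to compound 4 (0.10 log units; within the scatter), so configuration at a chain carbon counts in the pair of compound 3 and compound 4 but shows no effect in the other two. Within the data shown here, compound 3 and compound 4 are therefore separated from each other, while compound 1 and compound 2 remain within the scatter of both and no compound stands apart from all the others.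

On these data alone, the mirror images of compound 3 and compound 4 remain open, so the full set of stereoisomers cannot yet be assessed in this assay. Also open, as far as these compounds go, is whether an amine in place of the methoxy group, or a longer chain, would produce a step larger than any arising from configuration here.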